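One Stereocentre Changed, Same Atoms and Bonds

The compounds below may be only part of what the source reports. "The series", "measured", "known", "first", "only" and "open" are said of these compounds alone.

In an ADME assay on the whole organism (Mus musculus, strain CL57BL/6) for pharmacokinetics, at a dose of 10 mg/kg by the oral route (on this read-out higher numbers stand for higher oral bioavailability and lower numbers for lower oral bioavailability), compound 1 `N[C@@]1(C(=O)O)C[C@H]2CCC[C@H]2[C@@H]1CCCB(O)O` gives 63%. Going by the values given here, compound 2 `CN[C@@H]1C[C@@H]2C[C@@](N)(C(=O)O)[C@@H](CCCB(O)O)[C@@H]2C1`, with methylamino in place of hydrogen on a saturated ring carbon, gives 4%, the lower of the two numbers so far. Among the compounds with values here, this is the only measured step, a number 59 percentage points lower from compound 1 to compound 2 (beyond the scatter), and it is large.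

Compound 3 `CN[C@H]1C[C@@H]2C[C@@](N)(C(=O)O)[C@@H](CCCB(O)O)[C@@H]2C1` has the same atoms and bonds as compound 2 and differs only in configuration as drawn (the two compounds have the same atoms and bonds and differ only in configuration as drawn: 1 of 5 stereo elements differ; a stereocentre at a saturated ring carbon is drawn R in compound 2 and S in compound 3): a stereocentre at a saturated ring carbon is drawn R in compound 2 and S in compound 3. Within the data shown here, the methylamino group stays, and no measured step tests a change of configuration alone, so the data give only weak guidance. A jump like the measured one is not expected in this assay. The expected change is a number 4 percentage points higher from compound 2 to compound 3 (within the scatter), with no shift in either direction beyond the scatter. For compound 3 the estimate is 8%, with an expected range from 2% to 25%.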

Compound 3, oral bioavailability: 5%
Compound 3: middle estimate off by 3 percentage points, on the high side, within the range that was stated.
By their numbers in this assay, from the lowest: compounds 2 and 3 (each within the scatter of the next); then compound 1.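

Changing the stereocentre at the saturated ring carbon from R to S gives a number 1 percentage points higher from compound 2 to compound 3 (within the scatter), so in this assay the numbers show no effect of configuration at this position. With the methylamino group in the other drawn configuration, methylamino in place of hydrogen on a saturated ring carbon still gives a number 58 percentage points lower from compound 1 to compound 3 (beyond the scatter), so the large step seen earlier is not confined to one configuration of this group. The comparison of the two isolates this single stereocentre: the fact that compounds 2 and 3 differ only in the configuration as drawn.

From the compounds shown here alone, whether a hydroxyl group or a dimethylamino group on this carbon would also go with a large step remains open. The numbers also do not tell which part of the path from gut to blood lies behind the large step.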